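A few compounds are considered here, and "the series" means these few. Any claim that something is new, unique, unknown or untested is made for them only; others in the source may bear on it.

Compound 1 `Cn1c(-c2ccc(NC(=O)CSc3nc4ccccc4o3)cc2)nc(-c2ccccc2)c1-c1ccccc1` is the weakest of the three measured compounds in a functional assay on HT-29 cells (Homo sapiens) for cytotoxicity, read by MTT assay, with a stated time of 24 h, tested at 16 ug/mL (on this read-out lower numbers stand for a weaker effect and higher numbers for a stronger effect at the one concentration tested), where compound 1 gives 56.2%. Compound 2 `Cn1nnnc1SCC(=O)Nc1ccc(-c2nc(-c3ccccc3)c(-c3ccccc3)n2C)cc1` gives 72.5%, and compound 3 `Cc1nnc(SCC(=O)Nc2ccc(-c3nc(-c4ccccc4)c(-c4ccccc4)n3C)cc2)s1` gives 83.3%. The steps among these three all concern the group on the sulfur: a number 16.3 percentage points higher from compound 1 to compound 2 (beyond the scatter), a number 27.1 percentage points higher from compound 1 to compound 3 (beyond the scatter) and a number 10.8 percentage points higher from compound 2 to compound 3 (beyond the scatter). Compound 4 `Cn1c(-c2ccc(NC(=O)CN3CCN(c4ccccc4)CC3)cc2)nc(-c2ccccc2)c1-c1ccccc1` departs from compound 1 in a different way: 4-phenylpiperazin-1-yl in place of (1,3-benzoxazol-2-yl)sulfanyl on a saturated chain carbon bound to a carbonyl carbon. This change removes the sulfur together with the five-membered aromatic ring with 2 hetero atoms and brings in a six-membered non-aromatic ring with 2 hetero atoms, so none of the three measured steps is a direct parallel. They show only that what sits at this position can move the read-out by a modest amount, and that the 1,3-benzoxazol-2-yl of compound 1 sits at the bottom of the measured set. Since every measured replacement at this position raised the number, a small rise is taken as somewhat more likely than a fall, but the estimate stays close to compound 1 and carries a wide range. The step is therefore expected to be a number 3.8 percentage points higher from compound 1 to compound 4 (within the scatter). Compound 4 is estimated at 60% in this assay, between 35% and 85%.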

Compound 4, a percentage reported as activity, at one concentration (the size of the read-out at that concentration, not a potency): 55.4%
Compound 4: the middle estimate sits 4.6 percentage points above what was measured, and the stated range covers the measured number.
By their numbers in this assay, from the lowest: compounds 4 and 1 (each within the scatter of the next); then compound 2; then compound 3.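

In this assay the exchange of (1,3-benzoxazol-2-yl)sulfanyl for 4-phenylpiperazin-1-yl, which removes the sulfur and the five-membered aromatic ring, gives a number 0.8 percentage points lower from compound 1 to compound 4 (within the scatter), making it the only step away from compound 1 shown here that does not carry the read-out beyond the scatter. The same group falls short of the two other sulfur-linked groups, with a number 17.1 percentage points lower from compound 2 to compound 4 (beyond the scatter) and a number 27.9 percentage points lower from compound 3 to compound 4 (beyond the scatter), so the higher numbers belong to the (1-methyl-1H-tetrazol-5-yl)sulfanyl and (5-methyl-1,3,4-thiadiazol-2-yl)sulfanyl groups rather than to sulfur-linked groups in general, and compound 1, which carries sulfur yet matches compound 4 within the scatter, goes against any such general rule. Nothing shown here explains these differences.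

The compounds shown leave open whether the piperazine ring or its phenyl group sets the number of compound 4, a question that a 4-methylpiperazin-1-yl or a morpholin-4-yl group at this place would help to separate. Also open, from the compounds shown here alone, is how these compounds compare in potency, since each number comes from a single concentration.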